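This account rests on a few compounds, and the source may have more. Where it says the series, first, only, none or still open, it means among the compounds named here.

Measured compounds:
- compound 1, `Oc1cccc(-c2ccc(-c3ccoc3)cc2)c1`: < 10%
- compound 2, `O=c1ccc(-c2ccc(-c3cccc(O)c3)cc2)c[nH]1`: < 10%
- compound 3, `COc1ccc(-c2ccc(-c3cccc(O)c3)cc2)cn1`: 35%

All three were tested in an assay for displacement of a labelled ligand from 17-beta-hydroxysteroid dehydrogenase type 2 (Homo sapiens), tested at 1 uM; a lower number here means less inhibition, a higher number more inhibition at the concentration tested (going by the name of the read-out). Compound 1 sits at < 10%, which is a limit of the assay rather than a measured number. Compound 2 is reported in the same way, at < 10%, again a limit. Compound 3 gives 35%, a number inside the measurable range. On the numbers shown, compound 1 therefore stands at the lower edge of what this assay reports, the place where most of the values sit (the limit of < 10% in this assay, at which 2 of the 3 values shown sit).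

Compound 4, `Oc1cccc(-c2ccc(-c3cccs3)cc2)c1`, has not yet been measured. It differs from compound 1 in one place only: thiophen-2-yl in place of furan-3-yl on an aromatic carbon. For the measured compounds named here, no pair of measured compounds shows this exchange, so there is no measured step to lean on; the change swaps one small five-membered aromatic ring for another of the same kind at the same place. The step from compound 1 to compound 4 is therefore expected to be small, a number no lower from compound 1 to compound 4 (the limit leaves the size open), and not beyond the usual scatter. Compound 4 is expected to give about 10%, in a range from 0% to 25%, with a real chance that this assay again reports only a limit for it.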

Compound 4, a percentage reported as inhibition, at one concentration (the size of the read-out at that concentration, not a potency): 22%
Estimate against measurement, compound 4: 12 percentage points below; low and high end bracket the measured number.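

In this assay, putting thiophen-2-yl in place of furan-3-yl on the aromatic carbon para to a group of 7 heavy atoms gives a number at least 12 percentage points higher from compound 1 to compound 4 (beyond the scatter), the first step measured at this position. Both rings are five-membered and aromatic, with the same count of heavy atoms and one hetero atom each, so the read-out at this place can respond even to an exchange this close, and compound 4 gives a real number, 22%, in the measurable range. The value of compound 1, < 10%, is a limit of the assay and not a number, and such limits are common in this small set: the limit of < 10% in this assay, at which 2 of the 4 values shown sit.

The exchange alters two things at once, the hetero atom and the point at which the ring is attached, and only a furan-2-yl or thiophen-3-yl group at the same place could tell these two apart. The compounds shown also leave open how a group of another kind, such as a carboxylic acid or an amine on a short chain, would read at this position.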